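Branching the ring-nitrogen substituent: propyl to isopropyl

The source may report more compounds than this note shows. Statements on the series, on what has been measured and on what is new or still open speak of the compounds shown alone.

Compound 1 `Cn1nccc1-c1ccccc1NCC1=NCCN1` gives 10 nM in an in vitro functional assay on cells (Fibroblast) for agonist activity at Alpha-1A adrenergic receptor (Homo sapiens); on this read-out higher numbers stand for an effect only at larger amounts of compound and lower numbers for an effect already at smaller amounts. Compound 2 `CCCn1nccc1-c1ccccc1NCC1=NCCN1` gives 251 nM, the highest of the two numbers seen so far; its nearest neighbour is compound 1, and the step of a 25-fold higher number from compound 1 to compound 2 (1.40 log units; beyond the scatter) is large. Compound 3 `CC(C)n1nccc1-c1ccccc1NCC1=NCCN1` differs from compound 2 by isopropyl in place of propyl on an aromatic nitrogen. Within the data shown here, no measured step concerns branching of this group; the only step known, from compound 1 to compound 2, concerns lengthening, so it offers no direct guide. The expectation for compound 3 is therefore a step of a 1.2-fold higher number from compound 2 to compound 3 (0.08 log units; within the scatter) not beyond the scatter, giving an estimated 300 nM with a range from 80 nM to 1200 nM.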

Compound 3, half-maximal effective concentration: < 100000 nM
Compound 3: a limit, no number; the forecaster's own chance of this, stated with the estimate: 5%; the middle value is on the limit's open side.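

Compound 3 gives < 100000 nM, a limit and not a number; the steps to it from compound 1 and compound 2 cannot be read. The compounds shown leave open how isopropyl compares with propyl on the aromatic nitrogen.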